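Adding a methoxy group to compound 2

The source may report more compounds than this note shows. Statements on the series, on what has been measured and on what is new or still open speak of the compounds shown alone.

Values in an ADME assay on MDCK cells (Canis lupus familiaris) for cytotoxicity, read by MTT assay, with a stated time of 72 h (a lower number here means that less compound is tolerated, a higher number that more compound is tolerated), for three compounds:
Compound 1 `Cc1nc([N+](=O)[O-])cn1CC(=O)Nc1ccc(F)cc1` gives 828000 nM
Compound 2 `Cc1nc([N+](=O)[O-])cn1S(=O)(=O)c1ccccc1` gives 1270000 nM
Compound 3 `Cc1nc([N+](=O)[O-])cn1CC(=O)Nc1ccccc1` gives 1140000 nM

Compound 2 stands within the scatter of both other compounds, so the three values set no order. The change from compound 2 to compound 4 `COc1ccc(S(=O)(=O)n2cc([N+](=O)[O-])nc2C)cc1` is methoxy in place of hydrogen on an aromatic carbon, para to a large group (methoxy in place of hydrogen on an aromatic carbon). Going by the values given here, no measured step covers methoxy. The closest is hydrogen in place of fluoro on an aromatic carbon (a 1.4-fold higher number from compound 1 to compound 3 (0.14 log units; within the scatter)), which stayed within the scatter. In this assay no step beyond the scatter is therefore expected, and the estimated change is a 1.2-fold lower number from compound 2 to compound 4 (0.06 log units; within the scatter) at most a small one. Compound 4 is expected at 1100000 nM with an estimated range of 600000 nM to 2000000 nM in this measurement.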

Compound 4, half-maximal cytotoxic concentration: 321000 nM
Beside the measured number, compound 4's estimate is 3.4-fold (0.53 log units) above it; measured number outside the range, below it.
By their numbers in this assay, from the lowest: compound 4; then compounds 1, 3 and 2 (each within the scatter of the next).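

In this assay, methoxy in place of hydrogen on an aromatic carbon, para to a large group, gives a 4.0-fold lower number from compound 2 to compound 4 (0.60 log units; beyond the scatter) and so is the first step shown that lies beyond the scatter. Going by these compounds alone, the step between fluoro and hydrogen did not show this, so the earlier compounds gave no sign that a change on this ring could move the number this far. On these data alone, whether an amine or a longer chain at the same place would give a step of similar size remains open. No measurement at hand gives a reason for this step.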